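A few compounds are considered here, and "the series" means these few. Any claim that something is new, unique, unknown or untested is made for them only; others in the source may bear on it.

In a functional assay on HOS cells (Homo sapiens) for inhibition, with a stated time of 72 h (a higher number here means a weaker inhibitor, a lower number a stronger inhibitor), compound 3 `NC1CCC(Nc2nc(NCc3ccc(-c4ccco4)nc3)c3ncn(C4CCCC4)c3n2)CC1` gives 44 nM and compound 2 `NC1CCC(Nc2nc(NCc3ccc(-c4cccc(F)c4)nc3)c3ncn(C4CCCC4)c3n2)CC1` gives 44 nM, while compound 1 `NC1CCC(Nc2nc(NCc3ccc(-c4ccco4)cc3)c3ncn(C4CCCC4)c3n2)CC1` gives 102 nM. Compound 3 therefore stands level with compound 2 at the lowest number of the three. Two measured steps lead to compound 3. Putting 6-(furan-2-yl)pyridin-3-yl in place of 4-(furan-2-yl)phenyl gives a 2.3-fold lower number from compound 1 to compound 3 (0.37 log units; beyond the scatter), and putting furan-2-yl in place of 3-fluorophenyl gives no change at the digits printed from compound 2 to compound 3 (within the scatter).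

Compound 4 `CC(C)(O)CNc1nc(NCc2ccc(-c3ccco3)nc2)c2ncn(C3CCCC3)c2n1` differs at another place, with 2-hydroxy-2-methylpropyl in place of 4-aminocyclohexyl on a nitrogen on an aromatic ring. Neither measured step touches this place, so their sizes are only a loose guide. Going by the values given here, all three measured compounds carry 4-aminocyclohexyl, so the data hold no example of its loss. Starting from compound 3 at 44 nM, a move to a higher number seems more likely than a move to a lower one, and it could exceed both measured steps. The expected change is an 8.0-fold higher number from compound 3 to compound 4 (0.90 log units; beyond the scatter), though this estimate is uncertain. For compound 4 the estimated value is 350 nM, with an expected range of 90 nM to 1400 nM.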

Compound 4, half-maximal inhibitory concentration: 560 nM
The estimate for compound 4 lay 1.6-fold (0.20 log units) below the measured number, within the range that was stated.
By their numbers in this assay, from the lowest: compounds 2 and 3 (each within the scatter of the next); then compound 1; then compound 4.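

Until now every compound carried 4-aminocyclohexyl, so nothing showed whether this position could be changed. In this assay, replacing that group with 2-hydroxy-2-methylpropyl on the aromatic-ring nitrogen gives a 13-fold higher number from compound 3 to compound 4 (1.10 log units; beyond the scatter), a step larger than either earlier one, so this position clearly affects the number. The hydrogen-bond donor and acceptor counts of the two groups are the same, so those counts do not separate them; the visible differences are the loss of the ring, the oxygen in place of nitrogen, and the smaller heavy-atom count.

Nothing shown here explains the rise. As far as these compounds go, it remains open whether the ring or the amine counts for more: 4-hydroxycyclohexyl would keep the ring without the amine, and 2-aminoethyl would keep an amine without the ring.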